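The source may hold more compounds than are shown below. What is called first, only, known or untested is meant among the compounds shown, and "the series" means these compounds.

Compound 1 `Cn1cc(-c2cc(C(F)(F)F)c3ncc(Cc4ccc5ncccc5c4)n3c2)cn1`: "not determined" (no result reported)
Compound 2 `Fc1cc(-c2ccsc2)cn2c(Cc3ccc4ncccc4c3)cnc12`: 444 nM

Going by the values given here, in a functional assay on EBC-1 cells (Homo sapiens) for antiproliferative activity, with a stated time of 72 h (a lower number here means a stronger inhibitor, a higher number a weaker inhibitor), compound 2 gives 444 nM as the only number so far, so it cannot yet be ranked against anything. Compound 3 `CCO/N=C(\C)c1cc(F)c2ncc(Cc3ccc4ncccc4c3)n2c1` keeps the shared core but loses the thiophen-3-yl on an aromatic carbon, and a group with no ring enters there a group of 6 heavy atoms (4 carbon, 1 nitrogen, 1 oxygen; no ring) in place of a group of 5 heavy atoms (4 carbon, 1 sulfur; one five-membered aromatic ring with 1 hetero atom), on an aromatic carbon in its place. Among the compounds with values here, no measured step shows what such a swap does. No shift beyond the usual scatter, in either direction, is therefore expected, with an estimated step of a 1.3-fold lower number from compound 2 to compound 3 (0.10 log units; within the scatter) that stays small. For compound 3 the estimated value is 350 nM with an expected range from 70 nM to 1700 nM in this measurement.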

Compound 3, half-maximal inhibitory concentration: 1480 nM
Beside the measured number, compound 3's estimate is 4.2-fold (0.63 log units) below it, within the range that was stated.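

In this assay, a ring-free group of 6 heavy atoms taking the place of the thiophen-3-yl brings a 3.3-fold higher number from compound 2 to compound 3 (0.52 log units; beyond the scatter). This gives the first sign that this aromatic carbon, para to a fused ring, is sensitive to what it carries, and of these two groups the thiophen-3-yl gives the stronger inhibitor. Nothing measured here explains the difference. Still open, as far as these compounds go, is whether the ring itself matters or some other feature of the two groups, and a phenyl ring or a simple amine at this carbon would help to separate these.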